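Methyl for Isopropyl on Two Related Amide Cores

This account rests on a few compounds, and the source may have more. Where it says the series, first, only, none or still open, it means among the compounds named here.

Compound 1 `CC(C)[C@H](NCCC1OCC(C)(C)CO1)C(=O)N[C@H]1[C@@H](OCc2ccccc2)O[C@H](COCc2ccccc2)[C@@H](OCc2ccccc2)[C@@H]1OCc1ccccc1`: 86.2%
Compound 2 `C[C@H](NCCC1OCC(C)(C)CO1)C(=O)N[C@H]1[C@@H](OCc2ccccc2)O[C@H](COCc2ccccc2)[C@@H](OCc2ccccc2)[C@@H]1OCc1ccccc1`: 90.3%
Compound 3 `CC(C)[C@H](NCCC1OCC(C)(C)CO1)C(=O)N[C@H]1C(O)O[C@H](CO)[C@@H](O)[C@@H]1O`: 85.1%

Of the compounds shown here, three have so far been tested in a functional assay on the whole organism (Ear, strain ICR) for inhibition, with Mus musculus as the target, with stated times of 30 min and 2 h, at a dose of 10 umol/kg by the oral route; on this read-out higher numbers stand for more inhibition at the one dose given (going by the name of the read-out) and lower numbers for less inhibition. Compound 1 and compound 2 share one core and differ only in the group on the saturated chain carbon bound to an amine nitrogen and a carbonyl carbon: the change is methyl in place of isopropyl on a saturated chain carbon bound to an amine nitrogen and a carbonyl carbon. On this read-out the step is a number 4.1 percentage points higher from compound 1 to compound 2 (within the scatter), so the two compounds cannot be separated by this measurement.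

Compound 3 carries a different core, with the same isopropyl group as compound 1 at the same place. The difference between the core of compound 1 and the core of compound 3 is not broken down here. In this assay compound 3 gives 85.1%, which stands within the scatter of both compound 1 and compound 2.

Compound 4 `C[C@H](NCCC1OCC(C)(C)CO1)C(=O)N[C@H]1C(O)O[C@H](CO)[C@@H](O)[C@@H]1O` has not yet been measured. It stands to compound 3 as compound 2 stands to compound 1: the change is methyl in place of isopropyl on a saturated chain carbon bound to an amine nitrogen and a carbonyl carbon, and the place is described in the same words in both pairs, so it is the same change on the second core. Because the step of a number 4.1 percentage points higher from compound 1 to compound 2 (within the scatter) was within the scatter on the first core, the step on the second core is expected to be small as well, estimated at a number 2.9 percentage points higher from compound 3 to compound 4 (within the scatter). Compound 4 is therefore expected to give about 88% in this assay, most likely between 76% and 97%.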

Compound 4, a percentage reported as inhibition, in the whole organism at one dose (the size of the read-out at that dose, not a potency): 86.8%
The estimate for compound 4 lay 1.2 percentage points above the measured number; measured number inside the range.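

On the core of compound 3, methyl in place of isopropyl gives, in this assay, a number 1.7 percentage points higher from compound 3 to compound 4 (within the scatter), so on this core too the change cannot be separated from the spread of repeated measurements. Set side by side, the steps on the two cores do not differ: the same change on two cores in this assay, a number 4.1 percentage points higher (within the scatter) from compound 1 to compound 2 and a number 1.7 percentage points higher (within the scatter) from compound 3 to compound 4, 2.4 percentage points apart, within the scatter of two such steps

Within these four compounds, then, the change carries from the core of compound 1 to the core of compound 3 with the same outcome, a step too small to be read on either core; this is agreement between two small steps and does not show that a larger effect of the change would carry over in the same way, nor does it extend to any other core or give a potency, the read-out being taken at a single dose.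

On these data alone, whether a longer chain, a phenyl ring or a carboxylic acid on the saturated chain carbon bound to an amine nitrogen and a carbonyl carbon would give a step beyond the scatter stays open. Also open, as far as these compounds go, is whether methyl and isopropyl could be told apart on either core at a lower dose.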